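Methoxy for bromo on the anilino ring of compound 2

A few compounds are considered here, and "the series" means these few. Any claim that something is new, unique, unknown or untested is made for them only; others in the source may bear on it.

Measured so far:
compound 1 `C=CC(=O)Nc1cccc(NC(=O)CSc2nc(Nc3ccccc3C)c3ccccc3n2)c1` — 30200 nM
compound 2 `C=CC(=O)Nc1cccc(NC(=O)CSc2nc(Nc3cccc(Br)c3)c3ccccc3n2)c1` — 11900 nM

Going by the values given here, in a functional assay on MGC-803 cells (Homo sapiens) for inhibition, read by MTT assay, with a stated time of 72 h (a lower number here means a stronger inhibitor, a higher number a weaker inhibitor), compound 2 gives the lowest of the two numbers, its nearest neighbour being compound 1 at 30200 nM; the only step known, a 2.5-fold lower number from compound 1 to compound 2 (0.40 log units; beyond the scatter), is modest but beyond the scatter. Compound 3 `C=CC(=O)Nc1cccc(NC(=O)CSc2nc(Nc3cccc(OC)c3)c3ccccc3n2)c1` differs from compound 2 by methoxy in place of bromo on an aromatic carbon. Among the compounds with values here, no measured step bears directly on this exchange: the one known step changes both the group and its place on the ring, so it says little about swapping bromo for methoxy at the same position. Compound 3 is therefore expected to stay close to compound 2, with a step of a 1.3-fold higher number from compound 2 to compound 3 (0.10 log units; within the scatter) in this assay that need not exceed the scatter. The value of compound 3 is estimated at 15000 nM, within 5000 nM to 45000 nM.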

Compound 3, half-maximal inhibitory concentration: 24200 nM
Compound 3: the middle estimate sits 1.6-fold (0.21 log units) below what was measured, and the stated range covers the measured number.
By their numbers in this assay, from the lowest: compound 2; then compounds 3 and 1 (each within the scatter of the next).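

In this assay the exchange of bromo for methoxy at one and the same place on the ring can now be read alone, and it comes to a 2.0-fold higher number from compound 2 to compound 3 (0.31 log units; beyond the scatter) as a modest step, so the number at this position depends on the group it carries. With 3-methoxyphenyl in place of 2-methylphenyl the change reads a 1.2-fold lower number from compound 1 to compound 3 (0.10 log units; within the scatter) and leaves these two compounds indistinguishable. So far, then, compound 2 is the only one of the three set apart from the others, and methoxy does not keep its lower number.

On these data alone, whether chloro, an amine or a carboxylic acid at this place would give a number like that of compound 2 stays open. No measurement at hand explains the step.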